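The source may hold more compounds than are shown below. What is called first, only, known or untested is meant among the compounds shown, and "the series" means these compounds.

Measured compounds:
- compound 1 `O=C(O)c1ccccc1-c1ccc(CCc2ncc(CC3CCOCC3)[nH]2)cc1`: 338 nM
- compound 2 `N#Cc1ccc(Cc2cnc(CCc3ccc(-c4ccccc4C(=O)O)cc3)[nH]2)cc1`: 5890 nM

In an in vitro functional assay on cells for agonist activity at Bombesin receptor subtype-3 (Homo sapiens), read by luminescence and calcium flux (on this read-out lower numbers stand for an effect already at smaller amounts and higher numbers for an effect only at larger amounts of compound), compound 2 stands highest of the two numbers; its nearest neighbour, compound 1, gives 338 nM. For the measured compounds named here, the one measured step, a 17-fold higher number from compound 1 to compound 2 (1.24 log units; beyond the scatter), was large. Compound 3 `N#Cc1cccc(Cc2cnc(CCc3ccc(-c4ccccc4C(=O)O)cc3)[nH]2)c1` differs from compound 2 by 3-cyanophenyl in place of 4-cyanophenyl on a saturated chain carbon bound to an aromatic carbon. Going by the values given here, no measured step moves a nitrile within its ring, so the measured step gives no direct guide here. Compound 3 is therefore expected to show a change of a 1.2-fold lower number from compound 2 to compound 3 (0.07 log units; within the scatter) relative to compound 2, not beyond the scatter. Compound 3 is estimated at 5000 nM, between 1500 nM and 16000 nM.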

Compound 3, half-maximal effective concentration: 812 nM
For compound 3 the middle estimate is 6.2-fold (0.79 log units) above the measured one; the whole stated range lies above it.
By their numbers in this assay, from the lowest: compound 1; then compound 3; then compound 2.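

In this assay, the place of the nitrile on the ring matters at this position, even though the atoms stay the same: 3-cyanophenyl in place of 4-cyanophenyl gives a 7.3-fold lower number from compound 2 to compound 3 (0.86 log units; beyond the scatter) and so a modest step. Oxan-4-yl still gives the lowest number of the three, yet the gap to 3-cyanophenyl, a 2.4-fold higher number from compound 1 to compound 3 (0.38 log units; beyond the scatter) here, is modest and much smaller than the gap to 4-cyanophenyl. On these data alone, it remains open whether an amine or a methoxy group on the same benzyl ring would show a similar dependence on its place. Nothing available explains why moving the nitrile shifts the number this much.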